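This account rests on a few compounds, and the source may have more. Where it says the series, first, only, none or still open, it means among the compounds named here.

Values in a functional assay on MCF7 cells (Homo sapiens) for cytotoxicity, read by MTT assay, with a stated time of 3 days; a higher number here means a weaker inhibitor, a lower number a stronger inhibitor:
compound 1 `COc1ccc(-c2ccccc2)cc1`: > 100 ug/mL (a limit)
compound 2 `COc1ccc(-c2cccc(O)c2)cc1`: 48 ug/mL
compound 3 `COc1ccc(-c2ccccc2)c(OC)c1`: > 100 ug/mL (a limit)

Compound 1 gives > 100 ug/mL, which is a limit and not a number. The series is largely held at this ceiling, with the limit of > 100 ug/mL in this assay, at which 2 of the 3 values shown sit. Going by the values given here, only compound 2 has a measured number so far.

Compound 4 `COc1ccc(-c2ccccc2)cc1OC` differs from compound 1 by methoxy in place of hydrogen on an aromatic carbon. This is methoxy in place of hydrogen on an aromatic carbon, ortho to a methoxy group.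

Among the compounds with values here, two measured steps bear on this change. The step to the hydroxy analogue is an at least 2.0-fold lower number from compound 1 to compound 2 (0.31 log units; beyond the scatter), but it involves a different group and is only a loose guide. The closer precedent is the same kind of replacement, a step that the two limits leave unreadable from compound 1 to compound 3. Compound 3 gives > 100 ug/mL, also a limit, so this precedent offers no size.

Resting on a step that the two limits leave unreadable from compound 1 to compound 3, no step beyond the scatter is expected in this assay, and a report at the limit is the likeliest outcome. The expected step is a step that the limit leaves unreadable from compound 1 to compound 4. For compound 4 the estimated value is 110 ug/mL, with an expected range from 50 ug/mL to 200 ug/mL.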

Compound 4, half-maximal inhibitory concentration: 45 ug/mL
Compound 4: the middle estimate sits 2.4-fold (0.39 log units) above what was measured; measured number outside the range, below it.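

In this assay, going by these compounds alone, methoxy in place of hydrogen, ortho to a methoxy group and meta to a group of 6 heavy atoms, gives the first readable step for this replacement: an at least 2.2-fold lower number from compound 1 to compound 4 (0.34 log units; beyond the scatter). Compound 3 carries the same replacement on another aromatic carbon and gives > 100 ug/mL, which is a limit and not a number. The replacement therefore does not read the same at both places, but the step to compound 3 cannot be read, so no size can be given for that difference, and the ceiling still holds much of the series: the limit of > 100 ug/mL in this assay, at which 2 of the 4 values shown sit.

It remains open whether this carbon responds to methoxy specifically or to other replacements as well, since no ethoxy, amine or carboxylic acid at this place stands among the compounds shown. It also remains open whether the methoxy of compound 4 would keep its step in this assay if the hydroxy of compound 2 were present on the same core, as the compounds shown do not combine the two groups.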